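The source may hold more compounds than are shown below. What is called first, only, known or untested is meant among the compounds shown, and "the series" means these compounds.

Compound 1 `O=C(c1nccs1)c1nc(NCc2cccnc2)nc2ccsc12`: 176 nM
Compound 2 `CCNC(=O)c1nc(NCc2cccnc2)nc2ccsc12`: 120 nM

In a functional assay on CHO-K1 cells for antagonist activity at adenosine receptor A2b (Homo sapiens), read by FLIPR and calcium flux (on this read-out higher numbers stand for weaker inhibition and lower numbers for stronger inhibition), compound 1 gives 176 nM, and compound 2 gives 120 nM. Within the data shown here, the only measured step, a 1.5-fold lower number from compound 1 to compound 2 (0.17 log units; within the scatter), lies within the scatter, so the two numbers cannot be told apart. Compound 3 `O=C(NC1CC1)c1nc(NCc2cccnc2)nc2ccsc12` differs from compound 2 by cyclopropyl in place of ethyl on an amide-type nitrogen. Among the measured compounds shown here, no measured step touches the group on this amide-type nitrogen, so nothing points to a direction; the single step from compound 1 to compound 2 only shows that a change at the carbonyl left the number within the scatter. Compound 3 is therefore expected to stay close to compound 2, with a 1.1-fold lower number from compound 2 to compound 3 (0.04 log units; within the scatter) estimated, at 110 nM, between 50 nM and 250 nM.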

Compound 3, half-maximal inhibitory concentration: 256 nM
Beside the measured number, compound 3's estimate is 2.3-fold (0.37 log units) below it; the whole stated range lies below it.
By their numbers in this assay, from the lowest: compounds 2, 1 and 3 (each within the scatter of the next, the first and the last beyond it).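

On the amide-type nitrogen, cyclopropyl in place of ethyl gives a 2.1-fold higher number from compound 2 to compound 3 (0.33 log units; beyond the scatter) in this assay and so shows that this group can move the number, though only modestly. By contrast, a 1.5-fold higher number from compound 1 to compound 3 (0.16 log units; within the scatter) leaves cyclopropylamino and 1,3-thiazol-2-yl on the carbonyl carbon impossible to tell apart, even though ethylamino and cyclopropylamino can be separated. As far as these compounds go, whether a longer chain such as propyl, or a chain carrying an amine such as dimethylaminoethyl, would shift the number further in either direction stays open. No measured evidence gives a reason for the step from ethyl to cyclopropyl.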